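Nitro to Methoxycarbonyl on a Benzamide Dithiocarbamate Scaffold

The source may hold more compounds than are shown below. What is called first, only, known or untested is meant among the compounds shown, and "the series" means these compounds.

Two compounds sharing a benzamide core joined through a dithiocarbamate linker have been examined in a functional assay on A-375 cells (Homo sapiens) for antiproliferative activity, read by CCK-8 assay, with a stated time of 72 h, tested at 8 uM; a lower number here means a weaker effect, a higher number a stronger effect of the compound at the concentration tested. Compound 1, `Nc1ccccc1NC(=O)c1ccc(CSC(=S)N2CCc3cc([N+](=O)[O-])ccc32)cc1`, carries a nitro group on the fused bicyclic portion; in this assay compound 1 gives 29.5%. Compound 2, `Nc1ccccc1NC(=O)c1ccc(CSC(=S)N2CCN(Cc3ccccc3)CC2)cc1`, replaces that bicyclic portion with a benzyl-substituted piperazine and in this assay compound 2 gives 29.3%. The two values lie within the usual scatter of each other, so neither compound can be set apart from the other on these numbers, and compound 1 simply stands at the upper end of a pair that reads essentially alike.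

Compound 3, `COC(=O)c1ccc2c(c1)CCN2C(=S)SCc1ccc(C(=O)Nc2ccccc2N)cc1`, keeps the core of compound 1 and changes only one substituent: methoxycarbonyl in place of nitro on an aromatic carbon. Among the compounds with values here, the group that leaves and the group that enters carry the same count of hydrogen-bond acceptors and no charge, and no measured pair shows what such a swap does here. The step from compound 1 to compound 3 in this assay is therefore expected to be small, a number 1.5 percentage points lower from compound 1 to compound 3 (within the scatter), with no direction beyond the scatter. Compound 3 is estimated at 28%, in a range from 15% to 42%.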

Compound 3, a percentage reported as inhibition, at one concentration (the size of the read-out at that concentration, not a potency): 79.2%
Beside the measured number, compound 3's estimate is 51.2 percentage points below it; the whole stated range lies below it.
By their numbers in this assay, from the lowest: compounds 2 and 1 (each within the scatter of the next); then compound 3.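

In this assay the substituent on this aromatic carbon turns out to matter a great deal: methoxycarbonyl in place of nitro gives a number 49.7 percentage points higher from compound 1 to compound 3 (beyond the scatter) on an otherwise unchanged compound. The two groups have the same counts of hydrogen-bond donors and acceptors, the same count of double bonds outside aromatic rings and no net charge, so a match in those counts does not make two groups interchangeable at this position. No measurement at hand accounts for the size of the step.

The compounds shown do not tell whether the gain comes from the methoxycarbonyl group itself or from the loss of nitro, and a carboxylic acid, a primary amide or a nitrile on the same aromatic carbon would speak to that. From the compounds shown here alone, it also stays open whether the gain would hold with the ester's methyl replaced by a longer chain, and whether a read-out taken at a single concentration would carry over to a potency.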